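A few compounds are considered here, and "the series" means these few. Any claim that something is new, unique, unknown or untested is made for them only; others in the source may bear on it.

Measured so far:
Compound 1 `S=C(N/N=C/c1cccs1)Nc1ccc(Cl)cc1`: 8300 nM
Compound 2 `S=C(N/N=C/c1cccs1)Nc1cccnc1`: 26000 nM
Compound 3 `S=C(N/N=C/c1cccs1)Nc1cccc2ccccc12`: 12700 nM

All three values come from a functional assay on U-251 cells (Homo sapiens) for inhibition, read by sulforhodamine B assay, with a stated time of 48 h; on this read-out lower numbers stand for stronger inhibition of growth and higher numbers for weaker inhibition of growth. Compound 1 has the lowest number of the three, but its gap to compound 3 lies within the scatter, so those two cannot be ranked. The number for compound 2 is higher than that of compound 1, and this gap lies beyond the scatter.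

Compound 4 `Cc1ccc(NC(=S)N/N=C/c2cccs2)cc1` keeps the core of compound 1 and differs in one place: methyl in place of chloro on an aromatic carbon. It carries methyl in place of chloro on an aromatic carbon, para to a large group. Among the measured compounds shown here, no measured pair here shows this swap, so the only guide is the spread of the values, which runs from compound 1 at 8300 nM to compound 2 at 26000 nM. In this assay, the expected change is small and slightly upward, with the estimated step of a 1.4-fold higher number from compound 1 to compound 4 (0.16 log units; within the scatter) staying within the scatter. The estimate for compound 4 is 12000 nM, with an expected range from 5000 nM to 28000 nM.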

Compound 4, concentration for 50% growth inhibition: 12600 nM
The estimate for compound 4 lay 1.1-fold (0.02 log units) below the measured number; measured number inside the range.
By their numbers in this assay, from the lowest: compounds 1, 4 and 3 (each within the scatter of the next); then compound 2.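

Among the compounds shown here, this is the first pair that differs in one place only, so it gives the first direct reading of a change on the six-membered aromatic ring of carbon only, para to a large group. In this assay, methyl in place of chloro gives a 1.5-fold higher number from compound 1 to compound 4 (0.18 log units; within the scatter), so the two compounds cannot be told apart, and at this position the methyl and chloro groups read alike. Nothing at hand accounts for this match.

The compounds shown leave open whether a different kind of group at this position, such as an amine, a carboxylic acid or a longer chain, would separate from compound 1 beyond the scatter. They also leave open whether methyl and chloro would still match elsewhere on that ring.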